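Lengthening the Chain on a Cytotoxicity-Inactive Core

A few compounds are considered here, and "the series" means these few. Any claim that something is new, unique, unknown or untested is made for them only; others in the source may bear on it.

In a functional assay on KB cells (Homo sapiens) for cytotoxicity, read by MTT assay, with a stated time of 3 days (a higher number here means a weaker inhibitor, a lower number a stronger inhibitor), compound 2 `C=C1c2c(C)nc(OC)c(C#N)c2N=CN1CCC` gives only a limit, > 50000 nM. Compound 1 `C=C1c2c(C)nc(OC)c(C#N)c2N=CN1CC` likewise reaches only a limit, > 50000 nM. The step that the two limits leave unreadable from compound 1 to compound 2 therefore cannot be sized, because of the limit of > 50000 nM in this assay, at which 2 of the 2 values shown sit. Compound 3 `C=C1c2c(C)nc(OC)c(C#N)c2N=CN1CCCCCC` differs from compound 2 by propyl in place of hydrogen on a saturated chain carbon, three bonds along the chain from an amine nitrogen in a ring. Among the measured compounds shown here, the single measured step gives no reading of whether a longer chain alters potency in this assay, so compound 3 is expected to stay near the same limit. Compound 3 is estimated at 60000 nM, with a likely range from 20000 nM to 200000 nM. The step that the limit leaves unreadable from compound 2 to compound 3 that this estimate means is expected to be none beyond the scatter.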

Compound 3, half-maximal inhibitory concentration: > 50000 nM
Compound 3: no number, only a limit; the forecaster's own chance of this, stated with the estimate: 85%; the middle value lies beyond the limit too.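

Among the compounds shown here, compound 1, compound 2 and compound 3 all reach only a limit in this assay, so no step among them can be read: the limit of > 50000 nM in this assay, at which 3 of the 3 values shown sit. From the compounds shown here alone, whether any chain on this core gives a measurable potency in this assay stays open.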